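This account rests on a few compounds, and the source may have more. Where it says the series, first, only, none or still open, it means among the compounds named here.

Measured in a functional assay on T98G cells (Homo sapiens) for inhibition, read by MTT assay, with a stated time of 72 h; a lower number here means a stronger inhibitor, a higher number a weaker inhibitor:
- compound 1 `CC1(C)CC(NC(=O)NCc2ccccc2)c2cc(Br)ccc2O1`: 38000 nM
- compound 2 `CC1(C)CC(NC(=O)Nc2ccccc2)c2cc(Cl)ccc2O1`: 34000 nM
- compound 3 `CC1(C)CC(NC(=O)Nc2ccccc2Cl)c2cc(Cl)ccc2O1`: 20000 nM

Compound 3 stands at 20000 nM, and its gaps to compound 1 and compound 2 both lie within the scatter, so these three numbers cannot be ranked. All three sit in one narrow band.

Next in the series is compound 4 `CC1(C)CC(NC(=O)NCc2ccccc2)c2cc(Cl)ccc2O1`, which has benzyl in place of 2-chlorophenyl on an amide-type nitrogen. Within the data shown here, no measured step covers this exact exchange. The nearest evidence is a 1.7-fold lower number from compound 2 to compound 3 (0.23 log units; within the scatter), which is chloro in place of hydrogen on an aromatic carbon. That step is small and gives no firm direction for the loss of the 2-chlorophenyl group. Compound 1 also carries benzyl on the amide-type nitrogen and gives 38000 nM, which keeps the expectation inside the same band. No step beyond the scatter is therefore expected in this assay, although a slightly higher number would fit the value of compound 1.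

The estimated change is a 1.5-fold higher number from compound 3 to compound 4 (0.18 log units; within the scatter). For compound 4 the expected value is 30000 nM, with an estimated range from 15000 nM to 60000 nM.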

Compound 4, half-maximal inhibitory concentration: 15000 nM
For compound 4 the middle estimate is 2.0-fold (0.30 log units) above the measured one; the range from low to high includes it.
By their numbers in this assay, from the lowest: compounds 4, 3, 2 and 1 (each within the scatter of the next, the first and the last beyond it).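

Among these compounds, on the amide-type nitrogen in this assay, benzyl in place of 2-chlorophenyl gives a 1.3-fold lower number from compound 3 to compound 4 (0.12 log units; within the scatter) and so does not separate the two groups, while benzyl in place of phenyl gives a 2.3-fold lower number from compound 2 to compound 4 (0.36 log units; beyond the scatter) and is the first step at this position to pass the scatter, though only modestly. Among the compounds shown here, the aromatic carbon of the core also shows a first step beyond the scatter: with benzyl on the nitrogen, chloro in place of bromo gives a 2.5-fold lower number from compound 1 to compound 4 (0.40 log units; beyond the scatter) and is likewise modest, but this rests on a single pair. No measurement bears on the reason for either step.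

Still open, going by these compounds, is whether a longer chain on the amide-type nitrogen, such as phenylethyl, or a carboxylic acid or an amine on the benzyl ring, would move the number further in this assay and beyond the scatter. Also open, on these data alone, is whether chloro in place of bromo gives a similar step when phenyl or 2-chlorophenyl stands on the nitrogen instead of benzyl.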